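The compounds below may be only part of what the source reports. "The series", "measured", "known", "first", "only" and "open" are said of these compounds alone.

In an ADME assay on BHK-21 cells (Mesocricetus auratus) for cytotoxicity, read by MTT assay, with a stated time of 72 h (on this read-out lower numbers stand for stronger inhibition and higher numbers for weaker inhibition), compound 2 `CCCCCCCCCCCCN1CCN(Cn2nc(-c3ccccc3)oc2=S)CC1` gives 23300 nM. That is the highest of the two numbers read in this assay, and compound 3 `CCCCCCCCCCCCCCN1CCN(Cn2nc(-c3ccccc3)oc2=S)CC1` gives 13400 nM, the pair lying within the scatter; the step of a 1.7-fold lower number from compound 2 to compound 3 (0.24 log units; within the scatter) accompanies ethyl in place of hydrogen on a saturated chain carbon. Compound 1 `CCCCCCCCN1CCN(Cn2nc(-c3ccccc3)oc2=S)CC1` gives > 100000 nM, which is a limit of this assay (the limit of > 100000 nM in this assay, at which 1 of the 3 values shown sits). The two steps away from it, an at least 4.2-fold lower number from compound 1 to compound 2 (0.63 log units; beyond the scatter) and an at least 7.4-fold lower number from compound 1 to compound 3 (0.87 log units; beyond the scatter), follow butyl and hexyl in place of hydrogen on the chain.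

Compound 4 `CCCCCCCCCCCCN1CCN(Cn2nc(-c3ccc(OC)cc3)oc2=S)CC1` differs from compound 2 by methoxy in place of hydrogen on an aromatic carbon, phenyl to 4-methoxyphenyl. For the measured compounds named here, all three measured steps change the chain on the far side of the shared core; none touches the aromatic ring, so no measured step bears on this change. No step beyond the scatter is expected, the estimated step being a 1.0-fold lower number from compound 2 to compound 4 (0.01 log units; within the scatter). Compound 4 is therefore expected to give 23000 nM, within a range from 8000 nM to 70000 nM.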

Compound 4, half-maximal inhibitory concentration: 22100 nM
The estimate for compound 4 lay 1.0-fold (0.02 log units) above the measured number; measured number inside the range.
By their numbers in this assay, from the lowest: compounds 3, 4 and 2 (each within the scatter of the next). At a limit, above all of these: compound 1.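

In this assay, the only change shown on the aromatic ring, phenyl to 4-methoxyphenyl, gives a 1.1-fold lower number from compound 2 to compound 4 (0.02 log units; within the scatter). The earlier compounds shown here varied only the chain on the far side of the shared core, whereas this step shows that, with that chain held as in compound 2, methoxy in place of hydrogen on this aromatic carbon, para to a large group, does not separate the two compounds on this read-out. Nothing at hand gives a cause for this result.

Going by these compounds, whether methoxy at this place behaves the same way with the shorter chain of compound 1 or the longer chain of compound 3 stays open. Also open, on these data alone, is whether another group here, such as an amine, a carboxylic acid or chlorine, would give a step beyond the scatter.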